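From Compound 1 to Compound 4: A Side-Chain Exchange

A few compounds are considered here, and "the series" means these few. Any claim that something is new, unique, unknown or untested is made for them only; others in the source may bear on it.

Among the measured compounds shown here, in an ADME assay on microsomes from liver (Homo sapiens) for metabolic stability, read by LC-MS, with a stated time of 10 min, tested at 0.5 uM (a higher number here means that more of the compound is left, a lower number that less of the compound is left), compound 1 (`c1ccc2c(c1)CN[C@@H](CN(CCCN1CCNCC1)[C@H]1CCCc3cccnc31)C2`) gives 100%, the highest of the three numbers measured so far. Compound 2 (`c1cnc2c(c1)CN[C@@H](CN(CCCN1CCNCC1)[C@H]1CCCc3cccnc31)C2`) gives 79%, and compound 3 (`c1cnc2c(c1)CCC[C@@H]2N(CCCN1CCNCC1)Cc1nc2ccccc2s1`) gives 50%. Both of these differ from compound 1 in the group on a saturated chain carbon bound to an amine nitrogen. The measured steps are a number 21 percentage points lower from compound 1 to compound 2 (beyond the scatter) and a number 50 percentage points lower from compound 1 to compound 3 (beyond the scatter), and between those two relatives there is a number 29 percentage points lower from compound 2 to compound 3 (beyond the scatter).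

Compound 4 (`c1ccc2c(c1)CN[C@@H](CN(CC[C@H]1CCCNC1)[C@H]1CCCc3cccnc31)C2`) keeps that group and changes another part of compound 1: piperidin-3-yl in place of (piperazin-1-yl)methyl on a saturated chain carbon, two bonds along the chain from an amine nitrogen. Cut one bond further out, the same difference reads 2-(piperazin-1-yl)ethyl to (piperidin-3-yl)methyl. For the measured compounds named here, no measured compound alters this part, so the three steps offer only an indirect guide. They show that replacing a single group in compound 1 can shift the number by a modest or a large amount, and all of them run downward from 100% in compound 1. A modest fall is therefore expected, though the data cannot exclude no change beyond the scatter. The expected step is a number 18 percentage points lower from compound 1 to compound 4 (beyond the scatter). Compound 4 is estimated at 82%, with an expected range of 55% to 100%.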

Compound 4, percent of the compound remaining: 93%
Compound 4: middle estimate off by 11 percentage points, on the low side; low and high end bracket the measured number.
By their numbers in this assay, from the lowest: compound 3; then compound 2; then compounds 4 and 1 (each within the scatter of the next).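

In this assay, the exchange of (piperazin-1-yl)methyl for piperidin-3-yl on a saturated chain carbon, two bonds along the chain from an amine nitrogen, gives a number 7 percentage points lower from compound 1 to compound 4 (within the scatter). The earlier steps shown here all concerned another group and all lay beyond the scatter, whereas this one shows that the part of compound 1 changed here can be altered without a step beyond the scatter. The entering ring carries one hetero atom in place of two and brings a defined stereocentre, yet this single pair offers no evidence on what, if anything, either feature contributes to the result.

The compounds shown leave open whether this tolerance extends to other groups at the same place, such as a morpholine ring, an open-chain dimethylamino group or a longer chain, and whether the opposite configuration of the piperidin-3-yl stereocentre would behave alike. They also leave open whether the same exchange would hold on compound 2 or compound 3, whose numbers, unlike that of compound 1, lie beyond the scatter of compound 4.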